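Adding a Second Chloro to an Amide at the Limit

The source may report more compounds than this note shows. Statements on the series, on what has been measured and on what is new or still open speak of the compounds shown alone.

Three amides built on one shared core have been tested in an ADME assay on Raji cells (Homo sapiens) for inhibition, with a stated time of 72 h; a higher number here means that more compound is needed for the effect, a lower number that less compound is needed. Compound 1 `C=C(C)C(=O)Nc1cccc(-c2nc3ccccc3s2)c1` carries a 1-methylethenyl group on the carbonyl carbon, compound 2 `CC(C)(CCl)C(=O)Nc1cccc(-c2nc3ccccc3s2)c1` a 1-(chloromethyl)-1-methylethyl group, and compound 3 `O=C(Nc1cccc(-c2nc3ccccc3s2)c1)c1cccnc1Cl` a 2-chloropyridin-3-yl group. In this assay compound 1 gives > 25000 nM, which is a limit of the assay rather than a number. Compound 2 likewise gives > 25000 nM, a limit. Compound 3 also gives > 25000 nM, again a limit. All three values sit at the limit of > 25000 nM in this assay, at which 3 of the 3 values shown sit, so none of the steps among them can be read: a step that the two limits leave unreadable from compound 1 to compound 2, a step that the two limits leave unreadable from compound 1 to compound 3 and a step that the two limits leave unreadable from compound 2 to compound 3 are each hidden by the limit.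

Compound 4 `O=C(Nc1cccc(-c2nc3ccccc3s2)c1)c1ccc(Cl)nc1Cl` differs from compound 3 in one place: chloro in place of hydrogen on an aromatic carbon. Among the compounds with values here, none of the measured steps has a readable size, so there is no basis for expecting a movement in this assay in either direction, and compound 3 itself stands only at a limit.

The expected step in this assay is a step that the limit leaves unreadable from compound 3 to compound 4, with the new compound most likely staying at the limit. Compound 4 is estimated at 35000 nM, within 10000 nM to 120000 nM.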

Compound 4, half-maximal effective concentration: > 25000 nM
Compound 4: only a limit was reported; the forecaster's own chance of this, stated with the estimate: 85%; the middle value lies beyond the limit too.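

In this assay compound 4 gives > 25000 nM, which is a limit and not a number. Its steps from compound 1, compound 2 and compound 3 therefore cannot be read, and all four compounds stand at the same limit: the limit of > 25000 nM in this assay, at which 4 of the 4 values shown sit.

The compounds shown leave open whether any of these groups on the carbonyl carbon, or the added chloro, changes the concentration needed, and by how much.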